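This account rests on a few compounds, and the source may have more. Where it says the series, first, only, none or still open, it means among the compounds named here.

In a functional assay on HT-29 cells (Homo sapiens) for antiproliferative activity, read by sulforhodamine B assay, with a stated time of 48 h (on this read-out higher numbers stand for weaker inhibition and lower numbers for stronger inhibition), compound 1 `CCc1ccccc1NS(=O)(=O)c1ccc(N2CCNC2=O)cc1` gives 240 nM and compound 2 `O=C1NCCN1c1ccc(S(=O)(=O)Nc2ccc3[nH]ccc3c2)cc1` gives 130 nM, and these two values lie within the usual scatter of each other. Compound 3 `O=C1NCCN1c1ccc(S(=O)(=O)Nc2ccc(C3CCCCC3)cc2)cc1` gives > 1000 nM, which is a limit of the assay and not a number. Among the compounds with values here, compound 1 therefore stands level with compound 2 within the scatter, and it has only one other measured number for comparison. The next compound to follow is compound 4 `Cc1cccc(NS(=O)(=O)c2ccc(N3CCNC3=O)cc2)c1`, which carries 3-methylphenyl in place of 2-ethylphenyl on a sulfonamide nitrogen. The measured compounds differ from one another in more than one place, so none of them shows directly what this exchange does. Within the data shown here, the expectation therefore starts from compound 1 at 240 nM, with compound 2 at 130 nM as the only nearby number. No change beyond the scatter is expected in this assay, although the wide gap to the limit seen for compound 3 leaves more room for a weaker result than a stronger one. The expected step of a 1.3-fold higher number from compound 1 to compound 4 (0.10 log units; within the scatter) is accordingly small. Compound 4 is expected at 300 nM, with an estimated range of 100 nM to 900 nM.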

Compound 4, half-maximal inhibitory concentration: 110 nM
Compound 4: the middle estimate sits 2.7-fold (0.44 log units) above what was measured; the range from low to high includes it.
By their numbers in this assay, from the lowest: compounds 4, 2 and 1 (each within the scatter of the next, the first and the last beyond it). At a limit, above all of these: compound 3.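

In this assay, the group on a sulfonamide nitrogen can change the result on its own: with the rest of the structure unchanged, 3-methylphenyl in place of 2-ethylphenyl gives a 2.2-fold lower number from compound 1 to compound 4 (0.34 log units; beyond the scatter). Within the data shown here, the earlier compounds differed from one another in more than one place, so this is the first step at this position that can be read directly, and it is a modest one towards stronger inhibition. Nothing in the data shown bears on why the number moves.

The exchange alters two things at once, the chain on the phenyl ring and the place where that chain stands, so the compounds shown cannot tell which of the two accounts for the step. Also open, as far as these compounds go, is how 2-methylphenyl and 3-ethylphenyl would behave on the same sulfonamide nitrogen, and whether a phenyl ring carrying a longer chain, an amine or a carboxylic acid would continue this step, cancel it or reverse it.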